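The compounds below may be only part of what the source reports. "The series", "measured", "known", "first", "only" and "open" are said of these compounds alone.

The series shares the core of compound 2 `O=[N+]([O-])c1cccc(CNc2cc(C(F)(F)F)cc3[nH]ncc23)c1`, a benzylamine whose ring carries a single substituent. In an assay for inhibition of Tryptophan 2,3-dioxygenase (Homo sapiens), with stated times of 10 min and 60 min (on this read-out higher numbers stand for weaker inhibition and lower numbers for stronger inhibition), compound 2 gives 5170 nM. Compound 3 `O=C(O)CNc1cccc(CNc2cc(C(F)(F)F)cc3[nH]ncc23)c1` carries (carboxymethyl)amino where compound 2 carries nitro. In this assay compound 3 gives only a limit, > 100000 nM, not a number. The step is therefore recorded as an at least 19-fold higher number from compound 2 to compound 3 (1.28 log units; beyond the scatter). Compound 1 `O=C1NCc2c(NCc3ccccc3[N+](=O)[O-])cccc21`, built on a different core, also gives only a limit in this assay, > 100000 nM. Compound 3 thus stands at the limit of > 100000 nM in this assay, at which 2 of the 3 values shown sit, and nothing finer than that is known about it.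

Compound 4 `FC(F)(F)c1cccc(CNc2cc(C(F)(F)F)cc3[nH]ncc23)c1` differs from compound 3 in one place: trifluoromethyl in place of (carboxymethyl)amino on an aromatic carbon. Within the data shown here, no measured step covers trifluoromethyl at this position. Among the measured compounds shown here, the only step through this position, an at least 19-fold higher number from compound 2 to compound 3 (1.28 log units; beyond the scatter), shows that installing (carboxymethyl)amino in place of nitro pushed the number to the limit; compound 4 removes the (carboxymethyl)amino again and installs a group with no hydrogen-bond donors or acceptors. Compound 4 is expected to recover much of what compound 3 lost, a large drop in the number, an at least 10-fold lower number from compound 3 to compound 4 (1.00 log units; beyond the scatter). For the measured compounds named here, for compound 4 in this assay the estimate is 10000 nM, with a range from 2500 nM to 60000 nM; the range is wide since compound 2 is the only anchor with a number.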

Compound 4, half-maximal inhibitory concentration: 12200 nM
For compound 4 the middle estimate is 1.2-fold (0.09 log units) below the measured one; the range from low to high includes it.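

In this assay, replacing (carboxymethyl)amino with trifluoromethyl gives an at least 8.1-fold lower number from compound 3 to compound 4 (0.91 log units; beyond the scatter), so the loss seen with compound 3 does not extend to every replacement of nitro at this position. A group with no hydrogen-bond donors or acceptors can therefore hold a measurable value here, although trifluoromethyl does not fully match nitro: a 2.4-fold higher number from compound 2 to compound 4 (0.37 log units; beyond the scatter) is a modest step beyond the scatter, much smaller than an at least 19-fold higher number from compound 2 to compound 3 (1.28 log units; beyond the scatter). The size of the recovery remains a bound, since compound 3 gives a limit of the assay and not a number: the limit of > 100000 nM in this assay, at which 2 of the 4 values shown sit.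

On these data alone, with only nitro, trifluoromethyl and (carboxymethyl)amino to compare at this position, it remains open whether the loss in compound 3 goes with the carboxylic acid, the amine nitrogen linking it to the ring or the whole chain, and a simple amine or a carboxylic acid set directly on the ring would separate these cases. As far as these compounds go, it is also open whether a nitrile or a halogen would match nitro here, and how any of these groups would behave elsewhere on the ring.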